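Acid Dissociation in Four Related Compounds

This account rests on a few compounds, and the source may have more. Where it says the series, first, only, none or still open, it means among the compounds named here.

Compound 2 `COc1ccccc1Oc1ccc2c(NCCCNCc3ccco3)ccnc2c1` was examined in a physicochemical assay for acid dissociation, and gave 9.28. Compound 1 `CCC(CC)c1ccc2c(NCCCNCc3ccco3)ccnc2c1` differs from it by pentan-3-yl in place of 2-methoxyphenoxy on an aromatic carbon; in this assay compound 1 gives 9.47, which reads as a number 0.19 log units higher from compound 2 to compound 1 (within the scatter). Compound 3 `COc1ccccc1Oc1ccc2c(NCCCNCc3cccc(OC)c3O)ccnc2c1` differs from compound 2 in its core by 2-hydroxy-3-methoxyphenyl in place of furan-2-yl on a saturated chain carbon bound to an amine nitrogen, and in this assay compound 3 gives 9.28, so that the pair reads as no change at the digits printed from compound 2 to compound 3 (within the scatter). Compound 4 `CCC(CC)c1ccc2c(NCCCNCc3cccc(OC)c3O)ccnc2c1` has not yet been measured in this assay. It differs from compound 3 by pentan-3-yl in place of 2-methoxyphenoxy on an aromatic carbon, the same change that separates compound 2 from compound 1, this time made on the core of compound 3 rather than the core of compound 2. Because that change earlier gave a number 0.19 log units higher from compound 2 to compound 1 (within the scatter), a step of about the same size is expected here, namely a number 0.19 log units higher from compound 3 to compound 4 (within the scatter). The expectation rests on a single earlier pair and on nothing more. Compound 4 is therefore estimated in this assay at 9.47, with a likely range from 9.2 to 9.75.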

Compound 4, acid dissociation constant: 9.47
Beside the measured number, compound 4's estimate shows no gap at the digits printed; measured number inside the range.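

In this assay, putting pentan-3-yl in place of 2-methoxyphenoxy on the core bearing 2-hydroxy-3-methoxyphenyl gives a number 0.19 log units higher from compound 3 to compound 4 (within the scatter) and so matches a number 0.19 log units higher from compound 2 to compound 1 (within the scatter) at the digits printed, while the other change in the set gives no change at the digits printed from compound 1 to compound 4 (within the scatter) on the pentan-3-yl core. Within the data shown here, both steps for this change lie within the scatter, so the match shows only that the reading stays inside the usual spread on these two cores; it does not show a real effect that travels from one core to the other, and two pairs cannot establish a rule for the series. Nothing available bears on why the numbers fall as they do.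

The compounds shown leave open whether the same agreement would hold with a carboxylic acid or an amine in place of pentan-3-yl on the aromatic carbon. They also leave open whether a longer chain between the two nitrogens would carry the change in the same way.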